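The source may report more compounds than this note shows. Statements on the series, on what has been measured and on what is new or still open speak of the compounds shown alone.

Compound 1 `O=C1NC(=S)/C(=C/c2ccc(Br)cc2)S1` gives 18.2% in a functional assay on HEp-2 cells (Homo sapiens) for cytotoxicity, read by MTT assay, with a stated time of 72 h, tested at 10 ug/mL; a higher number here means more inhibition of growth at the concentration tested, a lower number less inhibition of growth. On the numbers shown, compound 1 sits close to compound 2 `O=C1NC(=S)/C(=C/c2ccccc2Cl)S1`, which gives 21.2% in this assay, and to compound 3 `O=C1NC(=S)/C(=C/c2ccccc2F)S1`, which gives 11.2%, with neither gap reaching beyond the scatter. Compound 4 `O=C1NC(=S)/C(=C/c2ccc(F)cc2)S1` differs from compound 1 in one place: fluoro in place of bromo on an aromatic carbon. Among the compounds with values here, one measured step bears on this change, a halogen swap on the same aromatic carbon, a number 10 percentage points lower from compound 2 to compound 3 (within the scatter), which stayed within the scatter. The step is therefore expected to be small, if anything slightly downward, so that compound 4 is estimated at 14%, within 4% to 25%. This estimate means a step of a number 4.2 percentage points lower from compound 1 to compound 4 (within the scatter), expected to remain within the scatter.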

Compound 4, percent growth inhibition at one concentration: 30.1%
Compound 4: the middle estimate sits 16.1 percentage points below what was measured, and the stated range ends below it.
By their numbers in this assay, from the lowest: compounds 3, 1, 2 and 4 (each within the scatter of the next, the first and the last beyond it).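

In this assay, within the data shown here, putting fluoro in place of bromo on this aromatic carbon, para to a group of 8 heavy atoms, gives a number 11.9 percentage points higher from compound 1 to compound 4 (beyond the scatter), the first single-place change here to pass beyond the scatter. The earlier halogen swap, a number 10 percentage points lower from compound 2 to compound 3 (within the scatter), stayed within the scatter, so its outcome does not carry over to this position. Nothing shown accounts for the shift. The compounds shown leave open whether an amine, a methoxy group or a carboxylic acid on this carbon would raise or lower growth inhibition further.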